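Changing the Aryl Group of Compound 2

A few compounds are considered here, and "the series" means these few. Any claim that something is new, unique, unknown or untested is made for them only; others in the source may bear on it.

In a functional assay on U-87MG ATCC cells for antiproliferative activity against U-87 MG (Homo sapiens), read by spectrophotometry, with a stated time of 2 days (on this read-out higher numbers stand for weaker inhibition of growth and lower numbers for stronger inhibition of growth), compound 1 `COc1ccc(Nc2ncc(C(F)(F)F)c(N3Cc4cccc(N(C)S(C)(=O)=O)c4C3)n2)cc1C(F)(F)F` gives 29400 nM and compound 3 `CN(c1cccc2c1CN(c1nc(Nc3cccc(Oc4ccccc4)c3)ncc1C(F)(F)F)C2)S(C)(=O)=O` gives 19500 nM. From the compounds shown here alone, compound 2 `Cc1ccc(Nc2ncc(C(F)(F)F)c(N3Cc4cccc(N(C)S(C)(=O)=O)c4C3)n2)c(Cl)c1` gives > 30000 nM, which is a limit of the assay and not a number, so its exact standing is unknown. Compound 4 `CN(c1cccc2c1CN(c1nc(Nc3ccc(C(F)(F)F)cc3)ncc1C(F)(F)F)C2)S(C)(=O)=O` carries 4-(trifluoromethyl)phenyl in place of 2-chloro-4-methylphenyl on a nitrogen on an aromatic ring. Going by the values given here, one measured step bears on this change at the same place, an at least 1.0-fold higher number from compound 1 to compound 2 (0.00 log units; that floor lies within the scatter), and it shows nothing beyond the scatter. No change beyond the scatter is therefore expected, and the estimated step is an at least 1.2-fold lower number from compound 2 to compound 4 (0.07 log units; that floor lies within the scatter). For compound 4, the expected value is 25000 nM, within an estimated range of 13000 nM to 35000 nM.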

Compound 4, concentration for 50% growth inhibition: > 30000 nM
Compound 4: no number, only a limit; the forecaster's own chance of this, stated with the estimate: 45%; middle value at least 1.2-fold (0.07 log units) from the limit.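

In this assay compound 4 gives > 30000 nM, which is a limit of the assay and not a number. The step between compound 2 and compound 4 cannot be read because both stop at the same limit: the limit of > 30000 nM in this assay, at which 2 of the 4 values shown sit.

Going by these compounds alone, the one readable step is an at least 1.0-fold higher number from compound 1 to compound 4 (0.00 log units; that floor lies within the scatter), so 4-(trifluoromethyl)phenyl shows no gain in growth inhibition at this place, though the real gap may be larger.

Still open, from the compounds shown here alone, is how far compound 2 and compound 4 lie beyond the limit, and whether an aryl group carrying an amine or a carboxylic acid would give a measurable value here.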